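Ethyl in Place of Bromo: What to Expect

A few compounds are considered here, and "the series" means these few. Any claim that something is new, unique, unknown or untested is made for them only; others in the source may bear on it.

Of the compounds shown here, two sharing one core have been tested in a functional assay on A549 cells (Homo sapiens) for inhibition, read by MTT assay, with a stated time of 72 h, tested at 10 uM; a lower number here means less inhibition, a higher number more inhibition at the concentration tested (going by the name of the read-out). Compound 1 `CCOC(=O)C1=C(Nc2ccccc2)S/C(=C\c2cc(OC)c(O)c(OC)c2)C1=O` gives 19.2% in this assay. Compound 2 `CCOC(=O)C1=C(Nc2ccc(Br)cc2)S/C(=C\c2ccc[nH]2)C1=O` reaches only a limit of the assay in this assay, namely < 10%, so its true number is not known. Of the two values shown, one sits at that limit (the limit of < 10% in this assay, at which 1 of the 2 values shown sits). Compound 3 `CCOC(=O)C1=C(Nc2ccc(CC)cc2)S/C(=C\c2ccc[nH]2)C1=O` has not been measured yet. It differs from compound 2 in one place: ethyl in place of bromo on an aromatic carbon. Among the compounds with values here, no step between two measured compounds is available, so there is no measured guide to what this change does in this assay. The expectation is a small step, or none beyond the usual scatter, so that compound 3 is likely to stay near the limit. The step of a number no lower from compound 2 to compound 3 (the limit leaves the size open) is the estimated change. Compound 3 is therefore expected to give about 10%, within 0% to 25%.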

Compound 3, a percentage reported as inhibition, at one concentration (the size of the read-out at that concentration, not a potency): 17.5%
The estimate for compound 3 lay 7.5 percentage points below the measured number; the range from low to high includes it.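

Compound 2 stands at a limit of the assay, < 10%, which is not a number. In this assay, going from 4-bromophenyl to 4-ethylphenyl gives a number at least 7.5 percentage points higher from compound 2 to compound 3 (that floor lies within the scatter), so this place on the ring accepts ethyl and still yields a readable value, although the floor of the step does not establish a real rise. The true size of the step cannot be fixed, because one of its two ends is a limit: the limit of < 10% in this assay, at which 1 of the 3 values shown sits.

The compounds shown leave open whether another group at this place, such as an amine, a carboxylic acid or a longer chain like butyl, would move the inhibition clearly beyond the scatter. They also leave open whether a smaller methyl there would read any differently from ethyl.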